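Dropping the Ring Oxygen: Pentyl in Place of Cyclohexyloxy

The source may report more compounds than this note shows. Statements on the series, on what has been measured and on what is new or still open speak of the compounds shown alone.

Measured so far:
compound 1 `CC(C(=O)NCc1ccc(C(C)(C)C)nc1N1CCC(Cc2ccccc2)CC1)c1ccc(NS(C)(=O)=O)c(F)c1`: 0.3 nM
compound 2 `CCCCCCOc1nc(C(C)(C)C)ccc1CNC(=O)C(C)c1ccc(NS(C)(=O)=O)c(F)c1`: 2.7 nM
compound 3 `CC(C(=O)NCc1ccc(C(C)(C)C)nc1OC1CCCCC1)c1ccc(NS(C)(=O)=O)c(F)c1`: 2.5 nM

Of the compounds shown here, three on a shared core have been measured in an assay on cells for antagonist activity at transient receptor potential cation channel subfamily V member 1 (Homo sapiens), read by FLIPR and calcium flux, with a stated time of 6 min; on this read-out higher numbers stand for weaker inhibition and lower numbers for stronger inhibition. Compound 3 `CC(C(=O)NCc1ccc(C(C)(C)C)nc1OC1CCCCC1)c1ccc(NS(C)(=O)=O)c(F)c1` gives 2.5 nM, the second highest of the three numbers; its nearest neighbour is compound 2 with 2.7 nM, and compound 1 with 0.3 nM sits furthest away.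

Compound 4 `CCCCCc1nc(C(C)(C)C)ccc1CNC(=O)C(C)c1ccc(NS(C)(=O)=O)c(F)c1` has not yet been measured. It differs from compound 3 in one place: pentyl in place of cyclohexyloxy on an aromatic carbon. Among the compounds with values here, only one measured step bears on this, a 1.1-fold lower number from compound 2 to compound 3 (0.03 log units; within the scatter), where a chain and a ring were exchanged on the oxygen. Within the data shown here, no measured step removes the oxygen itself. Compound 4 is therefore expected to give a number close to that of compound 3, the expected step of a 1.6-fold higher number from compound 3 to compound 4 (0.20 log units; within the scatter) being small and toward a higher number. The estimate for compound 4 is 4 nM, with a range from 1 nM to 15 nM.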

Compound 4, inhibition constant: 1.9 nM
Compound 4: middle estimate off by 2.1-fold (0.32 log units), on the high side; measured number inside the range.
By their numbers in this assay, from the lowest: compound 1; then compounds 4, 3 and 2 (each within the scatter of the next).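

On the aromatic carbon next to the ring nitrogen, pentyl, which has no oxygen and no ring, stands with the two oxygen-linked groups in this assay, as the steps show: a 1.3-fold lower number from compound 3 to compound 4 (0.12 log units; within the scatter) and a 1.4-fold lower number from compound 2 to compound 4 (0.15 log units; within the scatter). Among these compounds, then, a number in this range requires neither the oxygen nor a ring in the group. Nothing measured here explains why these numbers lie together. The compounds shown leave open whether a short chain such as methyl, or a carboxylic acid, on this carbon would give a number in the same range.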